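A few compounds are considered here, and "the series" means these few. Any claim that something is new, unique, unknown or untested is made for them only; others in the source may bear on it.

Measured in an ADME assay on microsomes from liver (Homo sapiens) for metabolic stability (a lower number here means that the compound disappears faster, a higher number that the compound lasts longer), so far:
Compound 1 `CC(C)C(c1ccc(-c2ccc3cccc(F)c3c2)[nH]c1=O)N1CCN/C1=N\C#N` at 0.632 h
Compound 2 `CC(C)C(c1nnc[nH]1)c1ccc(-c2ccc3cccc(F)c3c2)[nH]c1=O` at 0.905 h
Compound 3 `CC(C)C(c1noc(=O)[nH]1)c1ccc(-c2ccc3cccc(F)c3c2)[nH]c1=O` at > 3 h (a limit, not a number)

Compound 3 gives no number, only a limit (the limit of > 3 h in this assay, at which 1 of the 3 values shown sits).

The next step leads to compound 4 `CC(C)C(CC(N)=O)c1ccc(-c2ccc3cccc(F)c3c2)[nH]c1=O`, with carbamoylmethyl entering on a saturated chain carbon bound to an aromatic carbon and a saturated chain carbon (a group of 4 heavy atoms (2 carbon, 1 nitrogen, 1 oxygen; no ring) in place of a group of 6 heavy atoms (2 carbon, 2 nitrogen, 2 oxygen; one five-membered aromatic ring with 3 hetero atoms), on a saturated chain carbon bound to an aromatic carbon and a saturated chain carbon). The five-membered aromatic ring of compound 3 leaves.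

Three measured steps change this same place. The first (a 1.4-fold higher number from compound 1 to compound 2 (0.16 log units; within the scatter)) stays within the scatter. The other two (an at least 4.7-fold higher number from compound 1 to compound 3 (0.67 log units; beyond the scatter) and an at least 3.3-fold higher number from compound 2 to compound 3 (0.52 log units; beyond the scatter)) go beyond it, and both end at compound 3. Among the compounds with values here, no measured compound carries carbamoylmethyl, so the size of the coming step is uncertain. With the ring of compound 3 gone, a return towards compound 1 (0.632 h) and compound 2 (0.905 h) is the working expectation.

A lower half-life is expected, with the estimated step of an at least 2.5-fold lower number from compound 3 to compound 4 (0.39 log units; beyond the scatter) as a rough size only. For compound 4 the expected value in this assay is 1.2 h (expected range 0.5 h to 3 h).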

Compound 4, half-life: < 0.0667 h
Compound 4 ended at the assay's limit; the forecaster's own chance of this, stated with the estimate: 15%; at least 17-fold (1.25 log units) between middle value and limit.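

In this assay compound 4 stands at a limit of the assay, not at a number: the limit of < 0.0667 h in this assay, at which 1 of the 4 values shown sits.

With carbamoylmethyl on this saturated chain carbon, the number falls in all three comparisons, each beyond the scatter: an at least 44-fold lower number from compound 3 to compound 4 (1.65 log units; beyond the scatter), an at least 13-fold lower number from compound 2 to compound 4 (1.13 log units; beyond the scatter) and an at least 9.4-fold lower number from compound 1 to compound 4 (0.97 log units; beyond the scatter). Within the data shown here, compounds 1, 2 and 3 all carry a five-membered ring at this place, and among them the only steps beyond the scatter lead up to compound 3, whereas compound 4, the one compound here with no ring at this place, shows that a change at the same carbon can also take the number far down, with the rest of the structure unchanged.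

Compound 4 loses the ring and brings in an open chain in a single step, so these compounds do not separate the effect of losing the ring from that of carbamoylmethyl itself. A carboxylic acid or a longer chain ending in the same amide at this carbon would show whether the low number belongs to open chains at this place in general or to carbamoylmethyl alone.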